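Sulfonyl sulfur group swap from compound 3 to compound 4

The source may hold more compounds than are shown below. What is called first, only, known or untested is meant among the compounds shown, and "the series" means these compounds.

Measured so far:
- compound 1 `O=C(NCc1ccc(Cl)nc1)Nc1ccc(S(=O)(=O)c2ccccc2)cc1`: 6 mL/min/kg
- compound 2 `Nc1ncc(CNC(=O)Nc2ccc(S(=O)(=O)c3ccccc3)cc2)cn1`: 3 mL/min/kg
- compound 3 `C[C@@H]1CN(S(=O)(=O)c2ccc(NC(=O)NCc3cccnc3)cc2)C[C@H](C)O1`: 17 mL/min/kg

Not yet measured: compound 4 `O=C(NCc1cccnc1)Nc1ccc(S(=O)(=O)N2CC3(COC3)C2)cc1`

All values come from an ADME assay on microsomes from liver (Homo sapiens) for pharmacokinetics, read by LC-MS, with a stated time of 60 min, tested at 1 uM; a higher number here means faster removal of the compound, a lower number slower removal. Compound 3, at 17 mL/min/kg, is the highest of the three, and its gaps to the other two compounds lie beyond the scatter.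

The change under study is a group of 7 heavy atoms (5 carbon, 1 nitrogen, 1 oxygen; 2 four-membered non-aromatic rings with 1 hetero atom each) in place of a group of 8 heavy atoms (6 carbon, 1 nitrogen, 1 oxygen; one six-membered non-aromatic ring with 2 hetero atoms), on a sulfonyl sulfur. Among the measured compounds shown here, the only measured step between two compounds differing in one place is a 2.0-fold lower number from compound 1 to compound 2 (0.30 log units; within the scatter). That step lies within the scatter and concerns a different place, the 2-aminopyrimidin-5-yl in place of 6-chloropyridin-3-yl, so it gives no direct size for the present change. For the measured compounds named here, no measured pair changes the group on the sulfonyl sulfur, and the data contain no measured compound with the entering group.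

The expected direction therefore rests only on where compound 3 stands: the other values are lower, with compound 1 at 6 mL/min/kg and compound 2 at 3 mL/min/kg. A moderate move is expected, with low confidence, and a result within the scatter of compound 3 would not be surprising. The estimated step is a 1.9-fold lower number from compound 3 to compound 4 (0.28 log units; within the scatter). For compound 4 the expected value is 9 mL/min/kg, with an estimated range of 4 mL/min/kg to 18 mL/min/kg.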

Compound 4, clearance: 7 mL/min/kg
Compound 4: middle estimate off by 1.3-fold (0.11 log units), on the high side; the range from low to high includes it.
By their numbers in this assay, from the lowest: compounds 2, 1 and 4 (each within the scatter of the next, the first and the last beyond it); then compound 3.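

In this assay, among the compounds shown here, the group on the sulfonyl sulfur proves able to shift the number: the group with 2 four-membered non-aromatic rings in place of 2,6-dimethylmorpholin-4-yl gives a 2.4-fold lower number from compound 3 to compound 4 (0.39 log units; beyond the scatter) and this is the first measured step at this place. It is also the only listed step that lies beyond the scatter, although a modest one, so this position has so far shown more response than the 2-aminopyrimidin-5-yl for 6-chloropyridin-3-yl change on the saturated chain carbon. The swap alters ring size, ring number and the 2 defined stereocentres together, and no measurement here bears on which of these matters for the step.

Open, on these data alone, is whether the step belongs to the loss of the two methyl groups or to the four-membered rings, a question that plain morpholin-4-yl or a single azetidine ring on the sulfonyl sulfur would address. Also open, as far as these compounds go, is whether the step carries over when 2-aminopyrimidin-5-yl replaces the pyridine at the other end of the urea.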